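Swapping the chain terminus: chloro to methylsulfanyl

A few compounds are considered here, and "the series" means these few. Any claim that something is new, unique, unknown or untested is made for them only; others in the source may bear on it.

Measured compounds:
Compound 1, `COCOCCCCCc1cnc(C(=O)CCCCCCc2ccccc2)o1`, gives 24.1 nM in an assay for inhibition of Fatty-acid amide hydrolase 1 (Rattus norvegicus), using a Dixon plot; on this read-out higher numbers stand for weaker inhibition and lower numbers for stronger inhibition.
Compound 2, `O=C(CCCCCCc1ccccc1)c1ncc(CCCCCCl)o1`, gives 5.2 nM in this assay.

Compound 2 holds the lowest, that is strongest, number of the two. Within the data shown here, the only step measured at this position, a 4.6-fold lower number from compound 1 to compound 2 (0.67 log units; beyond the scatter), shows that the group at the end of the chain matters, and that a small halogen beat a two-atom ether group there.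

Compound 3, `CSCCCCCc1cnc(C(=O)CCCCCCc2ccccc2)o1`, differs from compound 2 by methylsulfanyl in place of chloro on a saturated chain carbon, five bonds along the chain from an aromatic carbon. The methylsulfanyl group is, like methoxymethoxy, larger than chloro and carries one hydrogen-bond acceptor, yet it is smaller than methoxymethoxy. The step from compound 1 to compound 2 therefore suggests a drift back toward weaker inhibition, but a smaller one. Compound 3 is expected to show a 1.7-fold higher number from compound 2 to compound 3 (0.24 log units; within the scatter) in this assay. The estimate for compound 3 is 9 nM, ranging from 3 nM to 27 nM.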

Compound 3, inhibition constant: 8.1 nM
For compound 3 the middle estimate is 1.1-fold (0.05 log units) above the measured one; low and high end bracket the measured number.
By their numbers in this assay, from the lowest: compounds 2 and 3 (each within the scatter of the next); then compound 1.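

In this assay, among these compounds, the change from chloro to methylsulfanyl amounts to a 1.6-fold higher number from compound 2 to compound 3 (0.19 log units; within the scatter) and so does not separate these two end groups, which means that chloro is not the only group at this position to reach this range. Methylsulfanyl in place of methoxymethoxy gives a 3.0-fold lower number from compound 1 to compound 3 (0.47 log units; beyond the scatter) and thus keeps much of the improvement first seen with chloro, even though methylsulfanyl brings a sulfur atom and a hydrogen-bond acceptor that chloro lacks. No measurement here explains why these end groups rank as they do.

From the compounds shown here alone, it remains open whether an amine or a carboxylic acid at the end of the chain would stay in the range of compound 2 and compound 3. Going by these compounds, the effect of a bromo or an ethylsulfanyl group at this position also remains open.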